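This account rests on a few compounds, and the source may have more. Where it says the series, first, only, none or still open, it means among the compounds named here.

Measured so far in a functional assay on MCF7 cells (Homo sapiens) for antiproliferative activity, read by MTT assay, with a stated time of 72 h; a lower number here means a stronger inhibitor, a higher number a weaker inhibitor:
compound 1 `COc1cc(-n2cnc3ccc(-c4ccc(C(C)=O)cc4)cc32)cc(OC)c1OC` gives 1540 nM
compound 2 `COc1cc(-n2cnc3ccc(-c4ccccc4)cc32)cc(OC)c1OC` gives 2290 nM
compound 3 `COc1cc(-n2cnc3ccc(-c4cccc([N+](=O)[O-])c4)cc32)cc(OC)c1OC` gives 4560 nM

Compound 2 stands second highest of the three numbers. Its nearest neighbour is compound 1, its furthest is compound 3, and both gaps are within the scatter, so no order among the three can be read from these values. The two single-point steps that involve compound 2 are a 1.5-fold higher number from compound 1 to compound 2 (0.17 log units; within the scatter) and a 2.0-fold higher number from compound 2 to compound 3 (0.30 log units; within the scatter); each swaps one group for another on an aromatic carbon of the same phenyl and neither moves the number beyond the scatter.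

Compound 4 `COc1ccc(-c2ccc3ncn(-c4cc(OC)c(OC)c(OC)c4)c3c2)cc1` is the next member to be measured. It differs from compound 2 by methoxy in place of hydrogen on an aromatic carbon. This is the same kind of change as the two steps already seen, a single group entering on an aromatic carbon of the phenyl, and those steps were small. The expectation for compound 4 in this assay is therefore a step of a 1.1-fold lower number from compound 2 to compound 4 (0.06 log units; within the scatter), that is, no change beyond the scatter in either direction. On that basis compound 4 is estimated at 2000 nM, with a range from 900 nM to 4500 nM.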

Compound 4, half-maximal inhibitory concentration: 210 nM
Compound 4: middle estimate off by 9.5-fold (0.98 log units), on the high side; measured number below the stated range.
By their numbers in this assay, from the lowest: compound 4; then compounds 1, 2 and 3 (each within the scatter of the next, the first and the last beyond it).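

Substitution on this phenyl matters in this assay: the step of an 11-fold lower number from compound 2 to compound 4 (1.04 log units; beyond the scatter), with methoxy para to a large group, is the first single-group change from compound 2 to go beyond the scatter. The result is tied to the group and not to substitution as such, since the step of a 7.3-fold lower number from compound 1 to compound 4 (0.87 log units; beyond the scatter) keeps the place and exchanges only acetyl for methoxy. The step of a 22-fold lower number from compound 3 to compound 4 (1.34 log units; beyond the scatter) is larger still, but 3-nitrophenyl and 4-methoxyphenyl differ in both group and place, so that step cannot assign the change to either one alone.

The compounds shown leave open whether methoxy is needed as such at this place, or whether a hydroxyl, an ethoxy group, a longer alkoxy chain or an amine there would give a similarly low number, and also what methoxy would give elsewhere on the phenyl. No supporting data accompany these values to explain why methoxy and acetyl part so clearly at this place.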